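Extending a methylamide to a propylamide in a kinase-inhibitor-like series

A few compounds are considered here, and "the series" means these few. Any claim that something is new, unique, unknown or untested is made for them only; others in the source may bear on it.

Measured compounds:
- compound 1, `CNC(=O)c1cc(Oc2ccc(NC(=O)c3cc4cccnc4n(-c4ccc(OC)cc4)c3=O)cc2)ccn1`: "not determined" (no result reported)
- compound 2, `CNC(=O)c1cc(Oc2ccc(NC(=O)c3cc4cccnc4n(-c4ccc(C(F)(F)F)cc4Cl)c3=O)cc2)ccn1`: 2110 nM
- compound 3, `CNC(=O)c1cc(Oc2ccc(NC(=O)c3cc4cccnc4n(-c4ccc(F)c(Cl)c4)c3=O)cc2)ccn1`: "not determined" (no result reported)

In a functional assay on NCI-H460 cells (Homo sapiens) for antiproliferative activity, read by MTT assay, with a stated time of 72 h (on this read-out lower numbers stand for stronger inhibition and higher numbers for weaker inhibition), compound 2 gives 2110 nM. Compound 1 has no number in this assay, where compound 1 is recorded as "not determined" (no result reported), and one further compound, compound 3, likewise lacks one, recorded as "not determined" (no result reported), so compound 1 cannot be placed relative to any measured value. Compound 4, `CCCNC(=O)c1cc(Oc2ccc(NC(=O)c3cc4cccnc4n(-c4ccc(OC)cc4)c3=O)cc2)ccn1`, differs from compound 1 in a single spot: ethyl in place of hydrogen on a saturated chain carbon bound to an amide-type nitrogen. Within the data shown here, since no measured pair shows what such a chain extension does here, no direction can be read from the data, and the expected step is one that may stay within the usual scatter. Taking compound 2 as the only measured anchor, compound 4 is expected to give 3000 nM, within a range from 400 nM to 25000 nM.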

Compound 4, half-maximal inhibitory concentration: 1730 nM
For compound 4 the middle estimate is 1.7-fold (0.24 log units) above the measured one; low and high end bracket the measured number.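

Among these compounds, no step from compound 1 to compound 4 can be read from these results. Going by these compounds, what replacing methylcarbamoyl with propylcarbamoyl does in this assay stays open. No supporting evidence bears on this result.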